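The compounds below may be only part of what the source reports. "The series", "measured", "known", "first", "only" and "open" are said of these compounds alone.

Compound 3 `O=S(=O)(N[C@@H]1C2CCN(CC2)[C@@H]1Cc1cccnc1)c1ccccc1` was examined in an assay on a protein complex for binding affinity to Neuronal acetylcholine receptor; alpha4/beta2 (Homo sapiens); on this read-out lower numbers stand for stronger inhibition and higher numbers for weaker inhibition. In this assay compound 3 gives only a limit, > 10000 nM, and not a number. Two related compounds share that outcome. Compound 1 `CSc1ccc(NC(=O)N[C@@H]2C3CCN(CC3)[C@@H]2Cc2cccnc2)cc1` gives the limit > 10000 nM in this assay. Compound 2 `O=S(=O)(N[C@@H]1C2CCN(CC2)[C@@H]1Cc1cccnc1)c1ccc(Br)cc1` carries bromo where compound 3 carries hydrogen. In this assay compound 2 gives the limit > 10000 nM. Compound 3 therefore stands where every measured value stands, namely at the limit of > 10000 nM in this assay, at which 3 of the 3 values shown sit, and no ordering among the three can be read from such values.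

Compound 4 `NC(=O)Cc1ccc(S(=O)(=O)N[C@@H]2C3CCN(CC3)[C@@H]2Cc2cccnc2)cc1` differs from compound 3 in one place: carbamoylmethyl in place of hydrogen on an aromatic carbon. Going by the values given here, the only measured step on the same aromatic ring is a step that the two limits leave unreadable from compound 2 to compound 3, and its size stays hidden because a step that the two limits leave unreadable from compound 2 to compound 3 runs between two limits. Among the compounds with values here, no measured step therefore tells how large the change to compound 4 might be, in either direction.

Since every measured compound sits at the limit, compound 4 is expected to give about 15000 nM, within a range from 3000 nM to 60000 nM. The expected step is a step that the limit leaves unreadable from compound 3 to compound 4.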

Compound 4, inhibition constant: > 10000 nM
Compound 4 ended at the assay's limit; the forecaster's own chance of this, stated with the estimate: 75%; the middle value does not contradict the limit.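

No new step can be read from compound 4, since its comparisons with compound 2 and compound 3 run between limits and not numbers: the limit of > 10000 nM in this assay, at which 4 of the 4 values shown sit. The compounds shown leave open which change to the aromatic ring, if any, would give a measurable value in this assay.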